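Swapping a Methyl for an Amino Group on the Benzyl Arm

The source may hold more compounds than are shown below. What is called first, only, known or untested is meant among the compounds shown, and "the series" means these compounds.

Measured compounds:
compound 1, `Cc1cc(C(=O)O)ccc1C(C)N1CCC[C@H](O[C@H](CO)c2cc(Cl)cc(Cl)c2)[C@@H]1c1ccccc1`: "nd" (no result reported)
compound 2, `Cc1cc(C(=O)O)ccc1CN1CCC[C@H](O[C@H](CO)c2cc(Cl)cc(Cl)c2)[C@@H]1c1ccc(F)cc1`: "nd" (no result reported)
compound 3, `Cc1cc(C(=O)O)ccc1CN1CCC[C@H](O[C@H](CO)c2ccnc(Cl)c2)[C@@H]1c1ccccc1`: > 200000 nM

Three compounds built on a shared core were tested in an assay on isolated protein for activation of cGMP-dependent protein kinase 1 (Homo sapiens), read by ADP-Glo, with stated times of 30 min and 2 h; on this read-out lower numbers stand for an effect already at smaller amounts and higher numbers for an effect only at larger amounts of compound. For compound 1 no result is reported in this assay, so it gives "nd" (no result reported). Compound 2 likewise gives "nd" (no result reported). For compound 3 the assay reports a limit rather than a number, > 200000 nM, and this is where the limit of > 200000 nM in this assay, at which 1 of the 3 values shown sits, sits. Compound 1 therefore stands without a single number among the values shown: one companion has a limit, the other no entry at all.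

The unmeasured compound 4, `Nc1cc(C(=O)O)ccc1CN1CCC[C@H](O[C@H](CO)c2cc(Cl)cc(Cl)c2)[C@@H]1c1ccccc1`, differs from compound 1 by a group of 11 heavy atoms (8 carbon, 1 nitrogen, 2 oxygen; one six-membered aromatic ring of carbon only) in place of a group of 12 heavy atoms (10 carbon, 2 oxygen; one six-membered aromatic ring of carbon only), on an amine nitrogen in a ring. The change sits on an amine nitrogen in a ring of the shared core.

Going by the values given here, no step between measured compounds is available, so the size of the change cannot be read from any pair here. Compound 4 is expected to give about 150000 nM in this assay, with a range from 20000 nM to 300000 nM, and a limit rather than a number is considered likely.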

Compound 4, half-maximal effective concentration: 168000 nM
The estimate for compound 4 lay 1.1-fold (0.05 log units) below the measured number; the range from low to high includes it.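

In this assay, going by these compounds alone, compound 4 gives 168000 nM, while compound 1 has no single number, and no step between compound 1 and compound 4 can be read. The compounds shown leave open whether the 2-amino-4-carboxybenzyl group changes the result at all on the shared core.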